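The source may hold more compounds than are shown below. What is called first, only, known or untested is meant among the compounds shown, and "the series" means these compounds.

In a functional assay on HepG2 cells (Homo sapiens) for antiproliferative activity, read by MTT assay, with a stated time of 72 h (on this read-out higher numbers stand for weaker inhibition and lower numbers for stronger inhibition), compound 2 (`NC1=NC2(CCSCC2)N(OCCCOc2cccc(Cl)c2Cl)C(N)=N1`) gives 50 nM, the lower of the two numbers available and so the stronger inhibition. Compound 3 (`NC1=NC2(CCOCC2)N(OCCCOc2ccccc2Br)C(N)=N1`) gives 860 nM in this assay, a gap beyond the usual scatter of repeat measurements. These two compounds differ in more than one place, so the gap cannot be tied to a single change. Compound 1 (`COc1ccc(OCCCON2C(N)=NC(N)=NC23CCOCC3)cc1`) offers no number, its result in this assay being "not determined" (no result reported) for now.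

Compound 4 (`NC1=NC2(CCSCC2)N(OCCCOc2cccc(Br)c2)C(N)=N1`) has not yet been measured. It keeps the rest of compound 2 and carries 3-bromophenyl in place of 2,3-dichlorophenyl on an oxygen on a saturated carbon. Going by the values given here, no measured pair isolates a swap like this, so the size of the step is a judgement. Starting from compound 2 at 50 nM, a move upward seems likelier than a further drop. The expected step is a 3.0-fold higher number from compound 2 to compound 4 (0.48 log units; beyond the scatter) in this assay, towards weaker inhibition. Compound 4 is estimated at 150 nM, with 30 nM to 700 nM as the expected range.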

Compound 4, half-maximal inhibitory concentration: 90 nM
Compound 4: the middle estimate sits 1.7-fold (0.22 log units) above what was measured; low and high end bracket the measured number.
By their numbers in this assay, from the lowest: compounds 2 and 4 (each within the scatter of the next); then compound 3.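

Going by these compounds alone, compounds 2 and 4 form the first pair here that differs in one place, so this swap can finally be read by itself. In this assay, putting 3-bromophenyl in place of 2,3-dichlorophenyl on an oxygen on a saturated carbon gives a 1.8-fold higher number from compound 2 to compound 4 (0.26 log units; within the scatter), so this read-out does not separate the two groups in this pair, and the aryl group at this place can be changed this way without a clear loss of inhibition. No measurement at hand explains this result.

As far as these compounds go, the pair covers only these two substituted phenyl groups, so it remains open how a plain phenyl, or a phenyl carrying an amine or a carboxylic acid, would fare at this place. From the compounds shown here alone, the effect of a longer chain between the core and the aryl ether also remains open.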